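A few compounds are considered here, and "the series" means these few. Any claim that something is new, unique, unknown or untested is made for them only; others in the source may bear on it.

Measured in a functional assay on DU-145 cells (Homo sapiens) for cytotoxicity, read by trypan blue exclusion, with a stated time of 96 h; on this read-out lower numbers stand for stronger inhibition and higher numbers for weaker inhibition:
- Compound 1 `COc1ccc(NS(=O)(=O)/C=C/c2c(F)c(F)c(F)c(F)c2F)cc1[N+](=O)[O-]`: 100000 nM
- Compound 2 `COc1ccc(NS(=O)(=O)/C=C/c2ccccc2OC)cc1`: 5000 nM

In this assay, compound 2 has the lower of the two numbers, at 5000 nM, and its gap to compound 1 lies beyond the usual scatter. Compound 3 `COc1ccc(NS(=O)(=O)/C=C/c2ccc(OC)cc2OC)cc1` is built from compound 2 by a single change: methoxy in place of hydrogen on an aromatic carbon, with methoxy in place of hydrogen on an aromatic carbon. Within the data shown here, no measured pair shows the effect of a single change, so any forecast is loose. A modest move toward stronger inhibition is expected, though a result within the scatter remains possible. The estimated change is a 2.0-fold lower number from compound 2 to compound 3 (0.30 log units; within the scatter). Compound 3 is expected at 2500 nM, with an estimated range of 400 nM to 12000 nM.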

Compound 3, half-maximal inhibitory concentration: 15000 nM
The estimate for compound 3 lay 6.0-fold (0.78 log units) below the measured number; the measured number lies above the stated range.
By their numbers in this assay, from the lowest: compound 2; then compound 3; then compound 1.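

In this assay methoxy in place of hydrogen on this aromatic carbon, meta to a methoxy group and para to a large group, gives a 3.0-fold higher number from compound 2 to compound 3 (0.48 log units; beyond the scatter) as a modest loss of inhibition beyond the scatter. Among these compounds, this is the first single change that can be read, and it shows that this position responds to substitution, with methoxy weakening inhibition here. Nothing measured here explains the loss. As far as these compounds go, whether an amine or a carboxylic acid on this carbon would also weaken inhibition remains open.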